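The compounds below may be only part of what the source reports. "The series", "measured", "known", "first", "only" and "open" are said of these compounds alone.

In a functional assay on HCT-116 cells (Homo sapiens) for antiproliferative activity, read by MTT assay, with a stated time of 48 h (a lower number here means a stronger inhibitor, a higher number a weaker inhibitor), compound 1 `CCCCCCC(CCO)n1cnc2c(OC)ncnc21` gives > 50000 nM, which is a limit of the assay and not a number. Compound 2 `CCCCCCC(CCO)n1cnc2c(NC)ncnc21` gives > 50000 nM, likewise a limit, so it stands with no measured number at all. Going by the values given here, the one measured step, a step that the two limits leave unreadable from compound 1 to compound 2, replaces methoxy with methylamino on an aromatic carbon, and its size cannot be read. Both values sit at one boundary: the limit of > 50000 nM in this assay, at which 2 of the 2 values shown sit. Compound 3 `CCCCCCC(CCO)n1cnc2c(N(C)C)ncnc21` differs from compound 2 by methylamino to dimethylamino, which is methyl in place of hydrogen on a nitrogen on an aromatic ring. Among the compounds with values here, no measured step gives a size for this change. The expectation therefore rests on compound 2, with its limit of > 50000 nM, and no shift beyond the scatter is expected in either direction. The expected step is a number no higher from compound 2 to compound 3 (the limit leaves the size open). For compound 3 the estimated value is 50000 nM, with an expected range from 25000 nM to 100000 nM.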

Compound 3, half-maximal inhibitory concentration: > 50000 nM
Compound 3: no number, only a limit; the forecaster's own chance of this, stated with the estimate: 85%; the middle value sits exactly at the limit.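

No new step can be read among compound 1, compound 2 and compound 3 in this assay, because all three values are limits and not numbers: the limit of > 50000 nM in this assay, at which 3 of the 3 values shown sit.
The compounds shown leave open how far methoxy, methylamino and dimethylamino differ in this read-out.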